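Aryl Replacement on the Chain Carbon of Compound 1

A few compounds are considered here, and "the series" means these few. Any claim that something is new, unique, unknown or untested is made for them only; others in the source may bear on it.

Measured so far:
compound 1 `CSc1ccc(/C=C(/SCc2ccc(Cl)cc2)C(=O)c2ccc(Cl)cc2)cc1` — 25000 nM
compound 2 `CSc1ccc(/C=C(/SCc2ccc(Cl)cc2)C(=O)c2ccc(C(=O)O)cc2)cc1` — a limit, > 100000 nM
compound 3 `O=C(/C(=C\c1ccc(OCc2ccccc2)cc1)SCc1ccc(Cl)cc1)c1ccc(Cl)cc1` — 1000 nM

In a functional assay on DU-145 cells (Homo sapiens) for inhibition, read by trypan blue exclusion, with a stated time of 96 h (a higher number here means a weaker inhibitor of growth, a lower number a stronger inhibitor of growth), compound 1 gives 25000 nM, the highest of the two numbers obtained, with compound 3 the nearest measured neighbour. Compound 3 gives 1000 nM, and the step of a 25-fold lower number from compound 1 to compound 3 (1.40 log units; beyond the scatter) is the one large move in the set. Compound 2 reaches only the limit > 100000 nM, which is a limit of the assay and not a number (the limit of > 100000 nM in this assay, at which 1 of the 3 values shown sits); the step of an at least 4.0-fold higher number from compound 1 to compound 2 (0.60 log units; beyond the scatter) goes the other way from the change in compound 3.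

Compound 4 `O=C(/C(=C\c1ccc(O)c([N+](=O)[O-])c1)SCc1ccc(Cl)cc1)c1ccc(Cl)cc1` differs from compound 1 by 4-hydroxy-3-nitrophenyl in place of 4-(methylsulfanyl)phenyl on a double-bonded chain carbon bound to a double-bonded chain carbon. Among the compounds with values here, the step from compound 1 to compound 3 sits at the same place and bears most directly on it, but benzyloxy is not 4-hydroxy-3-nitrophenyl, and no measured compound carries hydroxy or nitro anywhere. The step from compound 1 to compound 2 shows that a polar substituent entering elsewhere raised the number past the limit. Taken together, no step beyond the scatter is expected in this assay, with the uncertainty leaning toward a higher number. Compound 4 is therefore estimated at 30000 nM, range 6000 nM to 100000 nM, a step of a 1.2-fold higher number from compound 1 to compound 4 (0.08 log units; within the scatter) expected.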

Compound 4, concentration for 50% growth inhibition: 10000 nM
Compound 4: the middle estimate sits 3.0-fold (0.48 log units) above what was measured, within the range that was stated.
By their numbers in this assay, from the lowest: compound 3; then compound 4; then compound 1. At a limit, above all of these: compound 2.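

In this assay the place on a double-bonded chain carbon bound to a double-bonded chain carbon now gives a second replacement that lowers the number, with a 2.5-fold lower number from compound 1 to compound 4 (0.40 log units; beyond the scatter) as the step for 4-hydroxy-3-nitrophenyl in place of 4-(methylsulfanyl)phenyl. The lowering seen earlier therefore does not depend on benzyloxy, and both changes made at this place go the same way, with compound 3 giving 1000 nM and compound 4 giving 10000 nM in the printed values. Nothing given here explains why the number moved with this change.

Hydroxy and nitro enter together in compound 4, so the shares of the two groups in this step stay open, as does the reading of a ring carrying only one of them. Also open, as far as these compounds go, is how an amine or a carboxylic acid on the aromatic ring at this place would read, and whether a longer chain in place of benzyloxy would take the number lower still.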